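Morpholine in Place of Piperidine: Estimating Compound 4

A few compounds are considered here, and "the series" means these few. Any claim that something is new, unique, unknown or untested is made for them only; others in the source may bear on it.

Measured compounds:
Compound 1, `O=c1c(CSC(=S)N2CCOCC2)coc2cc(Cl)ccc12`: 8100 nM
Compound 2, `O=c1c(CSC(=S)N2CCCCC2)coc2cc(Cl)ccc12`: 380 nM
Compound 3, `CCOC(=O)c1cc(=O)c2cc(CSC(=S)N3CCCCC3)ccc2o1`: 21900 nM

All three compounds were tested in a functional assay on MCF7 cells (Homo sapiens) for antiproliferative activity, read by MTT assay, with a stated time of 72 h; on this read-out lower numbers stand for stronger inhibition and higher numbers for weaker inhibition. Compounds 1 and 2 share one core and differ in a single place: morpholin-4-yl in place of piperidin-1-yl on a thiocarbonyl carbon. That single exchange gave a 21-fold higher number from compound 2 to compound 1 (1.33 log units; beyond the scatter), so compound 1 is a markedly weaker inhibitor than compound 2.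

Compound 3 carries a different core, and the difference between its core and that of compound 2 is not broken down here. Its number is the highest of the three, and the values show it to be well above both compound 1 and compound 2.

Compound 4, `CCOC(=O)c1cc(=O)c2cc(CSC(=S)N3CCOCC3)ccc2o1`, has not been measured. It is built from compound 3 by the same change that turned compound 2 into compound 1: morpholin-4-yl in place of piperidin-1-yl on a thiocarbonyl carbon. The place of the change is described in identical words for both pairs, so this is the same change, now made on a different core. Going by the values given here, only one earlier instance of this change is available, and it was seen on another core, so its size may not carry over exactly. Still, the expectation is that compound 3 to compound 4 brings a step of a 5.5-fold higher number from compound 3 to compound 4 (0.74 log units; beyond the scatter), which rests on the weakening seen in a 21-fold higher number from compound 2 to compound 1 (1.33 log units; beyond the scatter). Compound 4 is therefore expected to give about 120000 nM, with a plausible range from 30000 nM to 450000 nM; a number this high may also be reported only as a limit of the assay.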

Compound 4, half-maximal inhibitory concentration: > 25000 nM
Compound 4: a limit, no number; the forecaster's own chance of this, stated with the estimate: 40%; the middle value is on the limit's open side.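

Compound 4 has no exact number in this assay, only a limit of the assay: the limit of > 25000 nM in this assay, at which 1 of the 4 values shown sits.

As far as these compounds go, on the core of compound 3, the exchange of piperidin-1-yl for morpholin-4-yl on a thiocarbonyl carbon can therefore be read only as a floor, an at least 1.1-fold higher number from compound 3 to compound 4 (0.05 log units; that floor lies within the scatter), and the true size of the step stays unknown. Set beside the earlier step, this result neither confirms nor rules out that the change carries over from one core to the other with the same size, so it gives no measure of how well the step transfers in this series: the same change on two cores in this assay, a 21-fold higher number (1.33 log units; beyond the scatter) from compound 2 to compound 1 and an at least 1.1-fold higher number (0.05 log units; that floor lies within the scatter) from compound 3 to compound 4; the limit leaves it open whether they differ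

The compounds shown leave open how large the step really is on the core of compound 3, and a pair on that core with both members giving exact numbers would be needed to settle it. They also leave open whether another amine on the thiocarbonyl carbon, such as pyrrolidin-1-yl or dimethylamino, would follow the same course on both cores, or whether the difference between piperidin-1-yl and morpholin-4-yl is a special case.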